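The source may hold more compounds than are shown below. What is called first, only, known or untested is meant among the compounds shown, and "the series" means these compounds.

Measured so far in a functional assay on HT-29 cells (Homo sapiens) for antiproliferative activity, read by sulforhodamine B assay, with a stated time of 72 h; a lower number here means a stronger inhibitor, a higher number a weaker inhibitor:
- compound 1 `COc1ccccc1NC(=S)N/N=C/c1ccc2ccccc2n1`: > 100000 nM
- compound 2 `Cc1cccc(NC(=S)N/N=C/c2ccc3ccccc3n2)c1`: > 100000 nM
- compound 3 `S=C(NCc1ccccc1)N/N=C/c1ccc2ccccc2n1`: 75700 nM

The value of compound 1 in this assay is a limit of the assay, not a number. The value of compound 2 in this assay is likewise a limit. For the measured compounds named here, compound 3 is the only member of the series with a number in this assay; the two other values sit at the limit of > 100000 nM in this assay, at which 2 of the 3 values shown sit. Accordingly the steps of an at least 1.3-fold lower number from compound 1 to compound 3 (0.12 log units; that floor lies within the scatter) and an at least 1.3-fold lower number from compound 2 to compound 3 (0.12 log units; that floor lies within the scatter) are known only as floors, and the step that the two limits leave unreadable from compound 1 to compound 2 cannot be read at all.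

Next in line is compound 4 `NC(=S)N/N=C/c1ccc2ccccc2n1`, which differs from compound 3 in one place: hydrogen in place of benzyl on an amide-type nitrogen. Going by the values given here, the steps that bear on this change are those in which the group on the same amide-type nitrogen was swapped, from compound 1 and from compound 2 to compound 3; both floors lie within the scatter, so they give no direction for a move from benzyl to hydrogen. Among the compounds with values here, no measured step removes the group from this nitrogen altogether. Compound 4 is therefore expected to stay near compound 3, with a wide range: 100000 nM (30000 nM to 300000 nM), a step of a 1.3-fold higher number from compound 3 to compound 4 (0.12 log units; within the scatter), and a substantial chance that this assay reports only a limit for compound 4.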

Compound 4, half-maximal inhibitory concentration: 100000 nM
Estimate against measurement, compound 4: no gap at the digits printed, and the stated range covers the measured number.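

In this assay, for the compounds shown here, the first readable step that strips the group from the amide-type nitrogen down to hydrogen gives a 1.3-fold higher number from compound 3 to compound 4 (0.12 log units; within the scatter). Benzyl, with its six-membered aromatic ring of carbon, and hydrogen are therefore not told apart at this nitrogen, so the whole group can leave without a change beyond the scatter, which the earlier floors could not show. Hydrogen in place of 2-methoxyphenyl gives a number no higher from compound 1 to compound 4 (the limit leaves the size open), and hydrogen in place of 3-methylphenyl gives a number no higher from compound 2 to compound 4 (the limit leaves the size open). Going by these compounds alone, these two steps cannot be read in size, so the 2-methoxyphenyl and 3-methylphenyl groups cannot be placed against hydrogen, and the only readable comparison at this nitrogen remains the one between benzyl and hydrogen: (the limit of > 100000 nM in this assay, at which 2 of the 4 values shown sit).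

With a single readable step, the series does not show whether any group on this nitrogen can move the number beyond the scatter in either direction. A longer chain such as 2-phenylethyl, or a chain ending in an amine or a carboxylic acid, would test whether the flat result for benzyl and hydrogen holds beyond these two groups.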